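This account rests on a few compounds, and the source may have more. Where it says the series, first, only, none or still open, it means among the compounds named here.

Measured in an assay on HepG2 cells for activation of nuclear factor erythroid 2-related factor 2 (Homo sapiens), read by a luciferase reporter, with a stated time of 5 h; on this read-out higher numbers stand for an effect only at larger amounts of compound and lower numbers for an effect already at smaller amounts:
compound 1 `Fc1cccc(/C=C/c2ccccc2)c1`: 3100 nM
compound 2 `Cc1ccc(/C=C/c2cccc(F)c2)cc1`: 800 nM
compound 3 `COc1cccc(/C=C/c2ccccc2)c1OC`: 4700 nM

Compound 3 has the highest number of the three; against compound 1 the gap is within the scatter, against compound 2 beyond it. How the core of compound 3 differs from that of compound 1 is not broken down here.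

The step methyl in place of hydrogen on an aromatic carbon gave a 3.9-fold lower number from compound 1 to compound 2 (0.59 log units; beyond the scatter). Compound 4 `COc1cccc(/C=C/c2ccc(C)cc2)c1OC`, not yet measured, carries the same kind of change on the core of compound 3: methyl in place of hydrogen on an aromatic carbon. The place lines differ only in how the neighbouring group is described, para to a large group here, para to a group of 9 heavy atoms before.

Expected for compound 4 is a step of a 3.4-fold lower number from compound 3 to compound 4 (0.53 log units; beyond the scatter) in this assay, resting on the size seen for compound 2 (a 3.9-fold lower number from compound 1 to compound 2 (0.59 log units; beyond the scatter)). The expected value for compound 4 is 1400 nM, estimated between 600 nM and 3500 nM.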

Compound 4, half-maximal effective concentration: 1100 nM
Compound 4: the middle estimate sits 1.3-fold (0.10 log units) above what was measured, and the stated range covers the measured number.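

In this assay, methyl in place of hydrogen on an aromatic carbon gave a 4.3-fold lower number from compound 3 to compound 4 (0.63 log units; beyond the scatter), and the step on the core of compound 3 matches the earlier one in size: the same change on two cores in this assay, a 3.9-fold lower number (0.59 log units; beyond the scatter) from compound 1 to compound 2 and a 4.3-fold lower number (0.63 log units; beyond the scatter) from compound 3 to compound 4, 1.1-fold (0.04 log units) apart, within the scatter of two such steps. The change therefore carried over between these two cores with no difference that can be told apart from scatter. This rests on a single pair of steps with one group in one assay, so it shows neither a general rule for the series nor why the number falls.

Going by these compounds, whether an ethyl chain, a carboxylic acid or an amine at the same place would give a step of like size stays open. Also open, on these data alone, is whether the methyl step holds on cores other than these two.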